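The compounds below may be only part of what the source reports. "The series", "measured", "known", "first", "only" and "open" are said of these compounds alone.

Measured compounds and their values:

Compound 1 `COc1cc(OC)c2c(c1)C(C(O)c1ccc(O)cc1)OC2=O`: in an ADME assay on RAW264.7 cells (Mus musculus) for cytotoxicity, read by MTT assay, with a stated time of 24 h, in the presence of a further agent that is not named here (on this read-out higher numbers stand for weaker inhibition and lower numbers for stronger inhibition), compound 1 gives > 40000 nM, which is a limit of the assay.
Compound 2 `CCOc1ccc(C(O)C2OC(=O)c3c(OC)cc(OC)cc32)cc1`: in this assay compound 2 gives > 40000 nM, again a limit.
Compound 3 `CCCOc1ccc(C(O)C2OC(=O)c3c(OC)cc(OC)cc32)cc1`: in this assay compound 3 gives > 40000 nM, again a limit.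

Compound 1 therefore stands only at a limit in this assay, with no number of its own, and the same holds for its two neighbours, because every value shown sits at the limit of > 40000 nM in this assay, at which 3 of the 3 values shown sit. The new compound is compound 4 `C=CCCOc1ccc(C(O)C2OC(=O)c3c(OC)cc(OC)cc32)cc1`. It differs from compound 1 by but-3-en-1-yl in place of hydrogen on an oxygen on an aromatic ring. Among the compounds with values here, the steps that bear on this change are a step that the two limits leave unreadable from compound 1 to compound 2 and a step that the two limits leave unreadable from compound 1 to compound 3, both of which the two limits leave unreadable, so their size cannot be told. Nothing in these values shows any step beyond the scatter, and the expectation is that the step of a number no higher from compound 1 to compound 4 (the limit leaves the size open) is likewise not readable. Compound 4 is therefore expected to give 40000 nM, in the range 20000 nM to 80000 nM, most probably reported again only as a limit.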

Compound 4, half-maximal inhibitory concentration: > 40000 nM
Compound 4: only a limit was reported; the forecaster's own chance of this, stated with the estimate: 85%; the middle value lies on the limit itself.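

Within the data shown here, compound 4 gives only a limit in this assay and so no step linking it to compound 1, compound 2 or compound 3 can be read: the limit of > 40000 nM in this assay, at which 4 of the 4 values shown sit. The compounds shown leave open how large any of these values really is and whether the group on that oxygen affects it.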